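From hydroxy to acetoxy on compound 2

The source may hold more compounds than are shown below. What is called first, only, known or untested is meant among the compounds shown, and "the series" means these compounds.

Compound 1 `C=C1C(=O)O[C@]2(C)CC[C@@H]1C[C@H](O)[C@@]1(C)CC[C@H](O1)[C@](C)(O)CC[C@H]2O` and compound 2 `C=C1C(=O)O[C@]2(C)CC[C@@H]1C[C@H](O)[C@@]1(C)CC[C@H](O1)[C@](C)(O)CCC2=O` share one core. In a functional assay on HeLa cells (Homo sapiens) for cytotoxicity, read by MTT assay (on this read-out higher numbers stand for an effect only at larger amounts of compound and lower numbers for an effect already at smaller amounts), compound 1 gives < 20 ug/mL as a limit and not a number. In this assay compound 2 gives < 20 ug/mL and this too is only a limit. Compound 2 therefore stands without an exact number on the limit of < 20 ug/mL in this assay, at which 2 of the 2 values shown sit, as its reading. Compound 3 `C=C1C(=O)O[C@]2(C)CC[C@@H]1C[C@H](OC(C)=O)[C@@]1(C)CC[C@H](O1)[C@](C)(O)CCC2=O` carries acetyl in place of hydrogen on an oxygen on a saturated carbon and so turns hydroxy to acetoxy. In this assay the expected change a step that the limit leaves unreadable from compound 2 to compound 3 is estimated to stay within the usual scatter. Compound 3 is expected at 12 ug/mL with an estimated range from 4 ug/mL to 25 ug/mL on this read-out.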

Compound 3, concentration for half-maximal effect: < 20 ug/mL
Compound 3 gave a limit, no number; the forecaster's own chance of this, stated with the estimate: 60%; the middle value is on the limit's open side.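

No step from compound 2 to compound 3 can be read, as both results are limits and not numbers: the limit of < 20 ug/mL in this assay, at which 3 of the 3 values shown sit.
As far as these compounds go, whether turning hydroxy to acetoxy shifts the read-out in this assay at all, and by how much, stays open.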